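A few compounds are considered here, and "the series" means these few. Any claim that something is new, unique, unknown or untested is made for them only; others in the source may bear on it.

Measured compounds in a functional assay on B16 cells (Mus musculus) for cytotoxicity, read by MTT assay, with a stated time of 72 h; on this read-out lower numbers stand for stronger inhibition and higher numbers for weaker inhibition:

Compound 1, `CCN(CC)CCCOc1c(OCc2ccccc2)cc(O)c2c(=O)cc(-c3ccccc3)oc12`: 4900 nM
Compound 2, `CN(C)CCCCOc1c(OCc2ccccc2)cc(O)c2c(=O)cc(-c3ccccc3)oc12`: 3220 nM
Compound 3, `CN1CCN(CCCCOc2c(OCc3ccccc3)cc(O)c3c(=O)cc(-c4ccccc4)oc23)CC1`: 2370 nM

Compound 3 carries the lowest number of the three in this assay. Its distance from compound 1 is a 2.1-fold lower number from compound 1 to compound 3 (0.32 log units; beyond the scatter), a modest step; its distance from compound 2 is a 1.4-fold lower number from compound 2 to compound 3 (0.13 log units; within the scatter), so compound 2 and compound 3 cannot be told apart on these numbers.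

Compound 4, `Cc1ccc(COc2cc(O)c3c(=O)cc(-c4ccccc4)oc3c2OCCCCN2CCN(C)CC2)cc1`, differs from compound 3 by methyl in place of hydrogen on an aromatic carbon. Going by the values given here, no measured step touches this part of the molecule: every step recorded so far, a 1.5-fold lower number from compound 1 to compound 2 (0.18 log units; within the scatter), a 2.1-fold lower number from compound 1 to compound 3 (0.32 log units; beyond the scatter) and a 1.4-fold lower number from compound 2 to compound 3 (0.13 log units; within the scatter), changes only the amine at the end of the chain, and all of them are small. The data therefore give no ground for expecting a step beyond the scatter in either direction.

Compound 4 is estimated at 2400 nM, with a range from 1000 nM to 6000 nM, which means an expected step of a 1.0-fold higher number from compound 3 to compound 4 (0.01 log units; within the scatter).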

Compound 4, half-maximal inhibitory concentration: 3290 nM
Compound 4: the middle estimate sits 1.4-fold (0.14 log units) below what was measured; the range from low to high includes it.
By their numbers in this assay, from the lowest: compounds 3, 2, 4 and 1 (each within the scatter of the next, the first and the last beyond it).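

In this assay, the change from benzyloxy to (4-methylbenzyl)oxy gives the first step outside the amine at the end of the chain (a 1.4-fold higher number from compound 3 to compound 4 (0.14 log units; within the scatter)). Compound 3 and compound 4 cannot be told apart on these numbers, so a single methyl in place of hydrogen on this aromatic carbon, para to a large group, leaves the read-out within the usual scatter. Nothing available explains this result.

As far as these compounds go, it remains open whether a methoxy group, a chlorine atom or a carboxylic acid on the same carbon would stay equally close to compound 3. From the compounds shown here alone, it is also open whether the 4-methylbenzyl group would behave the same way with a diethylamino or dimethylamino group at the end of the chain.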